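Pyridin-3-yl in place of carbamoyl on the shared core

The source may report more compounds than this note shows. Statements on the series, on what has been measured and on what is new or still open speak of the compounds shown alone.

In a functional assay on MDA-MB-231 cells (Homo sapiens) for cytotoxicity, read by MTT assay, with a stated time of 24 h (on this read-out lower numbers stand for stronger inhibition and higher numbers for weaker inhibition), compound 1 (`O=C(O)c1ccc(-c2nc3cccnc3n2C2CCCC2)cc1`) gives 600 nM and compound 2 (`O=C(NCc1ccccc1)c1ccc(-c2nc3cccnc3n2C2CCCC2)cc1`) gives 620 nM while compound 3 (`NC(=O)c1ccc(-c2nc3cccnc3n2C2CCCC2)cc1`) gives 8000 nM as the highest number of the three. Compound 4 (`c1cncc(-c2ccc(-c3nc4cccnc4n3C3CCCC3)cc2)c1`) carries pyridin-3-yl in place of carbamoyl on an aromatic carbon, and the change is pyridin-3-yl in place of carbamoyl on an aromatic carbon with the rest of the structure the same.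

Among the measured compounds shown here, no measured compound carries pyridin-3-yl, so only indirect evidence bears on this step. The large 13-fold higher number from compound 1 to compound 3 (1.12 log units; beyond the scatter) and the equally large a 13-fold higher number from compound 2 to compound 3 (1.11 log units; beyond the scatter) set compound 3 apart from the other two. By contrast, a 1.0-fold higher number from compound 1 to compound 2 (0.01 log units; within the scatter) shows that the much larger benzylamino group leaves the number where the hydroxy group had it. A step toward a lower number in this assay is therefore expected, somewhat smaller than those two large steps and with wide uncertainty.

Compound 4 is expected at 1200 nM with 300 nM to 5000 nM as its estimated range. The estimated step reads a 6.7-fold lower number from compound 3 to compound 4 (0.82 log units; beyond the scatter) on this reasoning.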

Compound 4, half-maximal inhibitory concentration: > 10000 nM
Compound 4 was reported as a limit; the forecaster's own chance of this, stated with the estimate: 3%; middle value at least 8.3-fold (0.92 log units) from the limit.
By their numbers in this assay, from the lowest: compounds 1 and 2 (each within the scatter of the next); then compound 3. At a limit, above all of these: compound 4.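

Compound 4 is reported only as a limit: the limit of > 10000 nM in this assay, at which 1 of the 4 values shown sits.

Pyridin-3-yl on this aromatic carbon gives an at least 16-fold higher number from compound 1 to compound 4 (1.22 log units; beyond the scatter) and an at least 16-fold higher number from compound 2 to compound 4 (1.20 log units; beyond the scatter), so this place, where carboxy and benzylcarbamoyl gave matching numbers, does not accept every large group, and compound 4 is the only one shown without a carbonyl there. Against carbamoyl the change gives an at least 1.2-fold higher number from compound 3 to compound 4 (0.09 log units; that floor lies within the scatter), and with that floor within the scatter, the data show only that compound 4 is not below compound 3 by any readable margin, so the two weak compounds cannot be properly ordered.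

On these data alone, how far compound 4 lies beyond its limit stays open. So does whether the carbonyl itself matters, which a methyl ester, a plain phenyl ring, a pyridin-4-yl ring or an aminomethyl group at this place could begin to show.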